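This account rests on a few compounds, and the source may have more. Where it says the series, first, only, none or still open, it means among the compounds named here.

Going by the values given here, compound 2 `CC[C@H](C)[C@H](NC(=O)c1cccc(Cn2ccnc2)c1)C(=O)NC#N` is the weaker of the two compounds measured so far: in an assay on HEK293 cells for displacement of a labelled ligand from Type-2 angiotensin II receptor (Homo sapiens), tested at 10 uM (on this read-out lower numbers stand for a weaker effect and higher numbers for a stronger effect at the one concentration tested), compound 2 gives 9%. Compound 1 `CC[C@H](C)[C@H](NC(=O)c1cccc(Cn2ccnc2)c1)C(=O)NNS(=O)(=O)c1ccc(C)cc1` carries a ((4-methylphenyl)sulfonyl)amino group where compound 2 carries a cyano; in this assay compound 1 reaches 20%. Among the compounds with values here, the one measured step, a number 11 percentage points lower from compound 1 to compound 2 (beyond the scatter), came with cyano in place of ((4-methylphenyl)sulfonyl)amino on an amide-type nitrogen. Compound 3 `CC[C@H](C)[C@H](NC(=O)c1cccc(Cn2ccnc2)c1)C(=O)NS(=O)(=O)c1ccccc1` goes the other way at the same place: phenylsulfonyl in place of cyano on an amide-type nitrogen. Within the data shown here, the entering phenylsulfonyl group is closely related to what compound 1 carries, so that single step is the only guide, and it points to a modest gain because compound 1 stands at 20%. For compound 3 the expected step is a number 9 percentage points higher from compound 2 to compound 3 (within the scatter) in this assay. Compound 3 is therefore estimated at 18%, with a range from 5% to 35%.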

Compound 3, a percentage reported as inhibition, at one concentration (the size of the read-out at that concentration, not a potency): 24%
Beside the measured number, compound 3's estimate is 6 percentage points below it, within the range that was stated.
By their numbers in this assay, from the lowest: compound 2; then compounds 1 and 3 (each within the scatter of the next).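

In this assay, phenylsulfonyl in place of cyano on the amide-type nitrogen gives a number 15 percentage points higher from compound 2 to compound 3 (beyond the scatter), so a second sulfonyl-bearing group now stands clear of the cyano compound at this position. Replacing ((4-methylphenyl)sulfonyl)amino with phenylsulfonyl gives a number 4 percentage points higher from compound 1 to compound 3 (within the scatter), so the two sulfonyl-bearing groups cannot be told apart here, even though only the group in compound 1 has the extra amino link and methyl. Nothing measured here bears on the reason for these numbers.

The compounds shown leave open whether the aromatic ring matters, which a methylsulfonyl group on the same nitrogen would help to test. They also leave open how a quite different group, such as a carboxylic acid at this place, would compare in this assay.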